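The source may report more compounds than this note shows. Statements on the series, on what has been measured and on what is new or still open speak of the compounds shown alone.

Compounds measured so far:
compound 1, `COc1ccc2nc(C)cc(OCC(=O)Nc3cccc(C)c3)c2c1` — 193000 nM
compound 2, `COc1ccc(NC(=O)COc2cc(C)nc3ccc(OC)cc23)cc1` — 108000 nM

In a physicochemical assay for solubility, in phosphate buffer, measured as kinetic solubility, with a stated time of 1 h, at pH 7.4 (a lower number here means a less soluble compound, a higher number a more soluble compound), compound 2 gives the lower of the two numbers, and compound 1 gives the higher one, yet the gap between them is small. For the measured compounds named here, the single measured step, a 1.8-fold lower number from compound 1 to compound 2 (0.25 log units; within the scatter), comes from exchanging the aryl group on the amide-type nitrogen and stays within the scatter, so the two compounds cannot be ranked against each other.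

Compound 3, `COc1ccc2nc(C)cc(OCC(=O)Nc3cc(C)c(F)c(C)c3)c2c1`, alters the same position: 4-fluoro-3,5-dimethylphenyl in place of 4-methoxyphenyl on an amide-type nitrogen. Going by the values given here, only the step from compound 1 to compound 2 bears on this change, as it also swaps the aryl group on that nitrogen, and it moved the number little. Among the compounds with values here, no measured compound carries the entering 4-fluoro-3,5-dimethylphenyl group, so the data give no direct guide to its effect.

For compound 3 a step of a 2.7-fold lower number from compound 2 to compound 3 (0.43 log units; beyond the scatter) toward a lower number is expected, with considerable uncertainty. The estimate for compound 3 in this assay is 40000 nM, with a range from 10000 nM to 150000 nM.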

Compound 3, solubility: 31500 nM
The estimate for compound 3 lay 1.3-fold (0.10 log units) above the measured number; the measured number falls inside the stated range.
By their numbers in this assay, from the lowest: compound 3; then compounds 2 and 1 (each within the scatter of the next).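

In this assay the aryl group on the amide-type nitrogen can move the number beyond the scatter, which the earlier pair did not show. With the shared core unchanged, 4-fluoro-3,5-dimethylphenyl in place of 4-methoxyphenyl gives a 3.4-fold lower number from compound 2 to compound 3 (0.54 log units; beyond the scatter) and, in place of 3-methylphenyl, gives a 6.1-fold lower number from compound 1 to compound 3 (0.79 log units; beyond the scatter) with both steps running toward a lower number, so compound 3 stands apart from compound 1 and compound 2, which remain within the scatter of each other. Nothing measured here accounts for these steps.

On these data alone, it remains open whether the fluorine or the methyl groups of 4-fluoro-3,5-dimethylphenyl carry these steps, and whether a 4-fluorophenyl group on that nitrogen would give a similar number. Equally open, as far as these compounds go, is how the number would respond to an aryl group bearing an amine or a carboxylic acid on the amide-type nitrogen, and whether steps of this size would hold on a different core.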